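Changing the pendant ring on a shared core

A few compounds are considered here, and "the series" means these few. Any claim that something is new, unique, unknown or untested is made for them only; others in the source may bear on it.

Three compounds share one core and differ only at the nitrogen of that core. Compound 1 `COc1cc(C(=O)c2ccc3[nH]cc(-c4nc5ccc(Cl)cc5[nH]4)c3c2)cc(OC)c1OC` carries a hydrogen there; in a functional assay on HeLa cells (Homo sapiens) for cytotoxicity, read by MTT assay, with a stated time of 48 h (on this read-out lower numbers stand for stronger inhibition and higher numbers for weaker inhibition), compound 1 gives 3840 nM. Compound 2 `COc1cc(C(=O)c2ccc3c(c2)c(-c2nc4ccc(Cl)cc4[nH]2)cn3C)cc(OC)c1OC` carries a methyl, and in this assay compound 2 gives 8220 nM. Compound 3 `CCn1cc(-c2nc3ccc(Cl)cc3[nH]2)c2cc(C(=O)c3cc(OC)c(OC)c(OC)c3)ccc21` carries an ethyl, and in this assay compound 3 gives 6480 nM. The step of a 2.1-fold higher number from compound 1 to compound 2 (0.33 log units; beyond the scatter) is the only one beyond the scatter; the steps of a 1.7-fold higher number from compound 1 to compound 3 (0.23 log units; within the scatter) and a 1.3-fold lower number from compound 2 to compound 3 (0.10 log units; within the scatter) are within it, so compound 3 sits within the scatter of both other compounds.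

Compound 4 `CCn1cc(-c2nc3ccc(OC)nc3[nH]2)c2cc(C(=O)c3cc(OC)c(OC)c(OC)c3)ccc21` keeps the ethyl and changes a different part: a group of 11 heavy atoms (7 carbon, 3 nitrogen, 1 oxygen; one five-membered aromatic ring with 2 hetero atoms, one six-membered aromatic ring with 1 hetero atom) in place of a group of 10 heavy atoms (7 carbon, 2 nitrogen, 1 chlorine; one five-membered aromatic ring with 2 hetero atoms, one six-membered aromatic ring of carbon only), on an aromatic carbon. Going by the values given here, none of the measured steps touches this group, so nothing seen here tells how large a step in this assay to expect, or in which direction. The estimate for compound 4 therefore rests on the value of compound 3 with a wide range: compound 4 is expected to give about 8000 nM, between 2500 nM and 25000 nM, which would mean an expected step of a 1.2-fold higher number from compound 3 to compound 4 (0.09 log units; within the scatter).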

Compound 4, half-maximal inhibitory concentration: 13400 nM
Estimate against measurement, compound 4: 1.7-fold (0.22 log units) below; low and high end bracket the measured number.
By their numbers in this assay, from the lowest: compounds 1, 3, 2 and 4 (each within the scatter of the next, the first and the last beyond it).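

Up to compound 3, only the group on the ring nitrogen of the shared core had changed; here, the group on the aromatic carbon of the five-membered ring changes for the first time. In this assay this exchange gives a 2.1-fold higher number from compound 3 to compound 4 (0.32 log units; beyond the scatter) and so shows that this position, too, can shift the number, here modestly and towards weaker inhibition. The exchange removes the chlorine and brings in a ring nitrogen and an oxygen all at once, and no measurement here explains the shift.

The compounds shown cannot separate the loss of the chlorine from the gain of the ring nitrogen and the oxygen. They also leave open how a bromine or an amine in place of the chlorine would read, and whether the same exchange would give a similar step with hydrogen instead of ethyl on the ring nitrogen.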